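The compounds below may be only part of what the source reports. "The series", "measured", "known", "first", "only" and "open" are said of these compounds alone.

Going by the values given here, compound 3 `CCS(=O)(=O)CCn1cc[n+](C)c1/C=N/O` gives -2.96 in a physicochemical assay for lipophilicity (on this read-out lower numbers stand for lower lipophilicity and higher numbers for higher lipophilicity), the lowest of the three numbers measured so far. Compound 1 `C[n+]1ccn(CC[N+](C)(C)C)c1/C=N/O` gives -2.61 in this assay, and compound 2 `C[n+]1ccn(CCCC(C)(C)[N+](=O)[O-])c1/C=N/O` gives -2.18 there. Among the compounds with values here, the only measured step between two compounds that differ in a single place is a number 0.35 log units lower from compound 1 to compound 3 (beyond the scatter), and it exchanges one set of atoms for a different set rather than rearranging them.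

Compound 4 `C[n+]1ccn(CCCS(C)(=O)=O)c1/C=N/O` differs from compound 3 as follows: (methylsulfonyl)methyl in place of ethylsulfonyl on a saturated chain carbon, two bonds along the chain from an aromatic nitrogen. The two compounds have the same atoms joined differently. Within the data shown here, no measured step covers a shift of the sulfonyl along the chain in this way, so the measured step from compound 1 to compound 3 does not bear directly on it. With no comparable change measured, compound 4 is expected to show a number 0.06 log units higher from compound 3 to compound 4 (within the scatter) in this assay, that is, no step beyond the scatter. The estimate for compound 4 in this assay is -2.9, with an expected range from -3.3 to -2.5.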

Compound 4, distribution coefficient: -2.7
Beside the measured number, compound 4's estimate is 0.20 log units below it; the measured number falls inside the stated range.
By their numbers in this assay, from the lowest: compounds 3, 4 and 1 (each within the scatter of the next, the first and the last beyond it); then compound 2.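

Joining the same atoms differently, with (methylsulfonyl)methyl in place of ethylsulfonyl, gives a number 0.26 log units higher from compound 3 to compound 4 (within the scatter) in this assay, so this read-out does not separate these two sulfonyl arrangements at this position. The change from the group of compound 1 gives a number 0.09 log units lower from compound 1 to compound 4 (within the scatter) with the (methylsulfonyl)methyl arrangement, while the ethylsulfonyl step (a number 0.35 log units lower from compound 1 to compound 3 (beyond the scatter)) was beyond the scatter, so the earlier difference does not carry over to both arrangements. Methylsulfonyl in place of 1-methyl-1-nitroethyl gives a number 0.52 log units lower from compound 2 to compound 4 (beyond the scatter) and is the only new step beyond the scatter. No evidence is available that accounts for these steps.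

On these data alone, whether a longer chain carrying the sulfonyl would give a step beyond the scatter remains open. So does the number that this assay would give for an amine or a carboxylic acid at this position.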